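Swapping a cinnamate ester for fluorine on a nitrochromene

A few compounds are considered here, and "the series" means these few. Any claim that something is new, unique, unknown or untested is made for them only; others in the source may bear on it.

Compound 2 `COC(=O)/C=C/c1ccc2c(c1)C=C([N+](=O)[O-])C(C(F)(F)F)O2` was tested in an assay on 1321N1 cells for antagonist activity at P2Y purinoceptor 6 (Homo sapiens), read by FLIPR and calcium flux (a higher number here means a weaker inhibitor, a lower number a stronger inhibitor), and gave 2570 nM. In this assay compound 1 `O=[N+]([O-])C1=Cc2cccc(I)c2OC1C(F)(F)F` gave 4090 nM; the gap between these two values falls within the usual scatter, so neither can be called the stronger. Compound 3 `O=[N+]([O-])C1=Cc2cc(F)ccc2OC1C(F)(F)F` differs from compound 2 in one place: fluoro in place of 2-(methoxycarbonyl)ethenyl on an aromatic carbon. Without a measured step of this kind, only a modest shift toward a weaker inhibitor is expected, with the small iodo-bearing compound 1 at 4090 nM as the nearest guide. The step from compound 2 to compound 3 is therefore expected to be a 1.9-fold higher number from compound 2 to compound 3 (0.29 log units; within the scatter). Compound 3 is estimated at 5000 nM, within 1500 nM to 16000 nM.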

Compound 3, half-maximal inhibitory concentration: 1150 nM
Compound 3: the middle estimate sits 4.3-fold (0.64 log units) above what was measured; the whole stated range lies above it.
By their numbers in this assay, from the lowest: compound 3; then compounds 2 and 1 (each within the scatter of the next).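

In this assay, the 2-(methoxycarbonyl)ethenyl group proves dispensable at this aromatic carbon: fluoro in its place gives a 2.2-fold lower number from compound 2 to compound 3 (0.35 log units; beyond the scatter), a modest gain beyond the scatter. Activity here therefore does not depend on the larger group's carbonyl or its double bond, and the single fluorine atom does better. No measurement at hand explains this step. From the compounds shown here alone, whether fluoro itself matters, or any small group would serve, remains open, and a hydrogen, chloro or methoxy at this carbon would settle it. Going by these compounds, how an amine or a carboxylic acid would fare there is equally open.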